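The source may hold more compounds than are shown below. What is called first, only, known or untested is meant among the compounds shown, and "the series" means these compounds.

Measured so far:
compound 1 `Cc1ccc(OC[C@@H]2C[C@H]3C[C@H]3N2C)cn1` — 20 nM
compound 2 `Brc1ccc(OC[C@@H]2C[C@H]3C[C@H]3N2)cn1` — 46.5 nM
compound 3 `Cc1ccc(OC[C@@H]2C[C@@H]3C[C@@H]3N2)cn1` — 1.38 nM

In an assay on CHO-K1 cells for displacement of a labelled ligand from Neuronal acetylcholine receptor; alpha4/beta2 (Homo sapiens), read by scintillation counting (a higher number here means a weaker inhibitor, a lower number a stronger inhibitor), compound 3 gives 1.38 nM, the lowest number of the three; compound 1 stands well above it and compound 2 further still, both gaps beyond the scatter. Compound 4 `Cc1ccc(OC[C@@H]2C[C@H]3C[C@H]3N2)cn1` has not been measured. How it differs from compound 3: the two compounds have the same atoms and bonds and differ only in configuration as drawn: 2 of 3 stereo elements differ; a stereocentre at a saturated ring carbon is drawn S in compound 3 and R in compound 4; a stereocentre at a saturated ring carbon is drawn S in compound 3 and R in compound 4. For the measured compounds named here, no step between measured compounds covers this change. Compound 1 and compound 2 share the drawn configuration of compound 4 at the ring carbons, and in this assay compound 1 gives 20 nM while compound 2 gives 46.5 nM; this points to a rise in the number, beyond the scatter. Compound 4 is therefore expected at 15 nM, range 5 nM to 50 nM. The step this expects is an 11-fold higher number from compound 3 to compound 4 (1.04 log units; beyond the scatter).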

Compound 4, inhibition constant: 26.2 nM
The estimate for compound 4 lay 1.7-fold (0.24 log units) below the measured number; the measured number falls inside the stated range.
By their numbers in this assay, from the lowest: compound 3; then compounds 1, 4 and 2 (each within the scatter of the next, the first and the last beyond it).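

In this assay, the drawn configuration at the two ring carbons alone gives a 19-fold higher number from compound 3 to compound 4 (1.28 log units; beyond the scatter), a reading that rests on this: the fact that compounds 3 and 4 differ only in the configuration as drawn. Within the configuration of compound 4, methyl in place of bromo on an aromatic carbon gives a 1.8-fold lower number from compound 2 to compound 4 (0.25 log units; within the scatter), and hydrogen in place of methyl on an amine nitrogen in a ring gives a 1.3-fold higher number from compound 1 to compound 4 (0.12 log units; within the scatter). Of these three steps, only the change in configuration lies beyond the scatter.

Which of the two ring carbons carries that step stays open, as both differ together. Also open, as far as these compounds go, is how a chloro or methoxy group on that aromatic carbon, or a methyl on the amine nitrogen, reads in the configuration of compound 3.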